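Swapping Hydroxy for Amino on the One Measured Inhibitor

The source may report more compounds than this note shows. Statements on the series, on what has been measured and on what is new or still open speak of the compounds shown alone.

Compound 3 `COc1cccc(CNCc2c(C(=O)O)n(Cc3ccc(O)cc3)c3cc(C(C)C)ccc23)c1` is the only one of the three measured compounds that gives a number in a functional assay on Bel-7402 cells (Homo sapiens) for antiproliferative activity, read by MTT assay, with a stated time of 72 h (a lower number here means a stronger inhibitor, a higher number a weaker inhibitor), where compound 3 records 7080 nM. Compound 1 `COc1cccc(CNCc2c(C(=O)O)n(Cc3ccc(O)cc3)c3ccccc23)c1` gives only a limit in this assay, namely > 50000 nM. Compound 2 `COc1ccc(Cn2c(C(=O)O)c(CNCc3cc(OC)ccc3O)c3ccc(C)cc32)cc1` likewise gives only a limit in this assay, namely > 50000 nM. The data therefore rest largely on (the limit of > 50000 nM in this assay, at which 2 of the 3 values shown sit). Going by the values given here, the single measured step, an at least 7.0-fold lower number from compound 1 to compound 3 (0.84 log units; beyond the scatter), concerns isopropyl in place of hydrogen on an aromatic carbon and says nothing about the change now in question.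

Compound 4 `COc1cccc(CNCc2c(C(=O)O)n(Cc3ccc(N)cc3)c3cc(C(C)C)ccc23)c1` differs from compound 3 in one place: amino in place of hydroxy on an aromatic carbon. No measured step involves a hydroxy or an amino, so none of the shown compounds bears directly on this change, and the step from compound 1 to compound 3 offers no guidance on it. The account therefore expects no shift beyond the scatter, an estimated 1.0-fold lower number from compound 3 to compound 4 (0.00 log units; within the scatter). In this assay compound 4 is expected to give about 7000 nM, within an estimated range from 2500 nM to 20000 nM.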

Compound 4, half-maximal inhibitory concentration: 9570 nM
Beside the measured number, compound 4's estimate is 1.4-fold (0.14 log units) below it; the range from low to high includes it.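

In this assay, amino in place of hydroxy on the 4-hydroxybenzyl group gives a 1.4-fold higher number from compound 3 to compound 4 (0.13 log units; within the scatter), so the two groups cannot be told apart at this position in this pair. Going by these compounds alone, this is the first measured step at this place, para to a large group, as the earlier step concerned only the isopropyl group. Compound 4 joins compound 3 as a second compound with a number and not a limit, so the hydroxy is not required for a measurable value here.

The set offers few numbers for further comparison: the limit of > 50000 nM in this assay, at which 2 of the 4 values shown sit. Going by these compounds, whether a nitrile or a fluorine at this position would read the same stays open, as does whether the amino group would read the same on a core without the isopropyl group.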